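This account rests on a few compounds, and the source may have more. Where it says the series, first, only, none or still open, it means among the compounds named here.

Compound 1 `O=C(/C(=C\c1ccc(O)c([N+](=O)[O-])c1)SCc1ccc(Br)cc1)C1CCNC1` carries a pyrrolidin-3-yl group on the carbonyl carbon of the shared core. In a functional assay on DU-145 cells (Homo sapiens) for inhibition, read by trypan blue exclusion, with a stated time of 96 h (a higher number here means a weaker inhibitor of growth, a lower number a stronger inhibitor of growth), compound 1 gives only a limit, > 100000 nM, and not a number. Among the three values shown, compound 1 alone sits at this limit (the limit of > 100000 nM in this assay, at which 1 of the 3 values shown sits). Two other compounds of the same core do give numbers. Compound 2 `O=C(/C(=C\c1cc(Cl)c(O)c(Cl)c1)S(=O)(=O)Cc1ccc(Br)cc1)c1ccc(Br)cc1` gives 25000 nM in this assay. Compound 3 `Cc1ccc(CS/C(=C/c2cc([N+](=O)[O-])ccc2F)C(=O)c2ccc(Cl)cc2)cc1` gives 1000 nM in this assay. Compound 4 `O=C(/C(=C\c1ccc(O)c([N+](=O)[O-])c1)SCc1ccc(Br)cc1)c1ccc(Cl)cc1Cl` has not yet been measured. It differs from compound 1 in one place: 2,4-dichlorophenyl in place of pyrrolidin-3-yl on a carbonyl carbon. After this change, compound 4, like compound 2 and compound 3, holds a six-membered aromatic ring of carbon only on the carbonyl carbon, and both of those compounds gave measurable numbers. A step toward stronger growth inhibition, well beyond the usual scatter, is therefore expected, of about an at least 20-fold lower number from compound 1 to compound 4 (1.30 log units; beyond the scatter). Compound 4 is estimated at 5000 nM in this assay, with a range from 1000 nM to 30000 nM.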

Compound 4, concentration for 50% growth inhibition: 10000 nM
For compound 4 the middle estimate is 2.0-fold (0.30 log units) below the measured one, within the range that was stated.
By their numbers in this assay, from the lowest: compound 3; then compound 4; then compound 2. At a limit, above all of these: compound 1.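

Until now, no two compounds shown differed in only one place, so nothing could be tied to the group on the carbonyl carbon; compound 1 and compound 4 now supply such a pair. In this assay, 2,4-dichlorophenyl in place of pyrrolidin-3-yl on a carbonyl carbon gives an at least 10-fold lower number from compound 1 to compound 4 (1.00 log units; beyond the scatter), which shows that the group at this position can change growth inhibition beyond the scatter. Compound 1 gives only a limit, so the full size of this step remains unknown: the limit of > 100000 nM in this assay, at which 1 of the 4 values shown sits.

The compounds shown leave open whether the aromatic ring or its two chlorine atoms account for the step. Plain phenyl would separate these two parts of the change, and an open-chain amine would show whether the outcome with pyrrolidin-3-yl extends to another amine.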